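Trading a Methyl for Hydrogen on an Aromatic Nitrogen

The source may hold more compounds than are shown below. What is called first, only, known or untested is meant among the compounds shown, and "the series" means these compounds.

Three measured compounds share a core in which a substituted nitrogen bridges two aromatic parts. Compound 1 `CN(c1ccc(Oc2ncnc3sccc23)cc1)c1nccc(N2CCc3ccccc3C2)n1` gives 6390 nM in a functional assay on A549 cells (Homo sapiens) for inhibition, read by MTT assay, with a stated time of 72 h; on this read-out higher numbers stand for weaker inhibition and lower numbers for stronger inhibition. Among the three numbers it has the second highest: compound 3 `CNC(=O)c1cc(Oc2ccc(Nc3nccc(N4CCCC4)n3)cc2)ccn1` gives 3410 nM, which lies within the scatter of compound 1, while compound 2 `CN(c1ccc(Oc2ncnc3sccc23)cc1)c1nccc(N2CCCC2)n1` gives 15100 nM, and the step of a 2.4-fold higher number from compound 1 to compound 2 (0.37 log units; beyond the scatter) is modest but beyond the scatter. Compound 4 `c1ccc2c(c1)CCN(c1ccnc(Nc3ccc(Oc4ncnc5sccc45)cc3)n1)C2` differs from compound 1 by hydrogen in place of methyl on a nitrogen on an aromatic ring. Among the compounds with values here, no measured pair differs in this place alone; the one step that exists, a 2.4-fold higher number from compound 1 to compound 2 (0.37 log units; beyond the scatter), concerns another part of the molecule and does not bear on it directly. Compound 3 carries a hydrogen on this nitrogen, yet its other parts differ too, so it offers only a loose hint. The change is therefore expected to move the number by little, a 1.4-fold lower number from compound 1 to compound 4 (0.15 log units; within the scatter), staying within the scatter. Compound 4 is estimated at 4500 nM, with a range from 1500 nM to 13000 nM.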

Compound 4, half-maximal inhibitory concentration: 6750 nM
The estimate for compound 4 lay 1.5-fold (0.18 log units) below the measured number, within the range that was stated.
By their numbers in this assay, from the lowest: compounds 3, 1 and 4 (each within the scatter of the next); then compound 2.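

Within the data shown here, this is the only pair here that differs at this nitrogen alone, and in this assay, hydrogen in place of methyl gives a 1.1-fold higher number from compound 1 to compound 4 (0.02 log units; within the scatter), a step within the scatter. On the core of compound 1, then, the methyl can be removed without a detectable change in the number, so this level of inhibition does not depend on that methyl. No measurement at hand explains why the number holds steady.

As far as these compounds go, whether hydrogen and methyl are just as interchangeable with pyrrolidin-1-yl in the molecule remains open: compound 2 has no partner that differs from it at this nitrogen alone. From the compounds shown here alone, it is also open how the number would respond to something larger on this nitrogen, such as an ethyl group, a longer chain or an acetyl group.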